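Cyclopropylamino to isopropylamino on a shared core

A few compounds are considered here, and "the series" means these few. Any claim that something is new, unique, unknown or untested is made for them only; others in the source may bear on it.

Measured so far:
compound 1, `CCCc1nn(C)c2c(NC3CC3)nc(/C=C/c3nc(C)c(C)nc3C)nc12`, 706000 nM
compound 2, `CCCc1nn(C)c2c(NC(C)C)nc(/C=C/c3nc(C)c(C)nc3C)nc12`, 342000 nM
compound 3, `CCCc1nn(C)c2c(NC3CC3)nc(CCc3cccnc3)nc12`, 564000 nM

In a functional assay on L02 cells (Homo sapiens) for inhibition, read by Griess assay, with stated times of 1 h and 24 h (a higher number here means a weaker inhibitor, a lower number a stronger inhibitor), compound 1 gives 706000 nM, while compound 2 gives 342000 nM. The change between them, (isopropyl in place of cyclopropyl on a nitrogen on an aromatic ring), made a step of a 2.1-fold lower number from compound 1 to compound 2 (0.31 log units; beyond the scatter).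

Compound 3 carries a different core from compound 1; that difference between the two cores is not broken down here. Compound 4, `CCCc1nn(C)c2c(NC(C)C)nc(CCc3cccnc3)nc12`, is not yet measured and differs from compound 3 by isopropyl in place of cyclopropyl on a nitrogen on an aromatic ring, the same change as from compound 1 to compound 2, at the same kind of place.

A step of about the same size is expected for compound 4, namely a 2.0-fold lower number from compound 3 to compound 4 (0.30 log units; within the scatter), because the earlier step was a 2.1-fold lower number from compound 1 to compound 2 (0.31 log units; beyond the scatter). Compound 4 is therefore estimated at 280000 nM in this assay, with a range from 120000 nM to 650000 nM.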

Compound 4, half-maximal inhibitory concentration: 514000 nM
Compound 4: middle estimate off by 1.8-fold (0.26 log units), on the low side; low and high end bracket the measured number.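

In this assay the step of a 1.1-fold lower number from compound 3 to compound 4 (0.04 log units; within the scatter) stands on the core of compound 3, and the two steps for this change do not differ beyond what repeated measurement allows: the same change on two cores in this assay, a 2.1-fold lower number (0.31 log units; beyond the scatter) from compound 1 to compound 2 and a 1.1-fold lower number (0.04 log units; within the scatter) from compound 3 to compound 4, 1.9-fold (0.27 log units) apart, within the scatter of two such steps. Isopropyl in place of cyclopropyl on a nitrogen on an aromatic ring is therefore compatible with a similar step on both cores, though only the step on the core of compound 1 lies beyond the scatter. Two pairs do not show that the step is a general one, or that it would carry to any further core.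

On these data alone, what a cyclobutyl group or a longer chain such as n-butyl would do on that nitrogen stays open. So does whether a chain ending in an amine or a carboxylic acid would follow the same course on either core.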